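From a pyrrole to a bromofuran on a shared core

The source may report more compounds than this note shows. Statements on the series, on what has been measured and on what is new or still open speak of the compounds shown alone.

Compound 1 `N#C/C(=C\c1c(F)c(F)c(F)c(F)c1F)C(=O)c1ccc[nH]1` gives 64000 nM in a functional assay on A2780 cells (Homo sapiens) for inhibition, read by MTT assay, with a stated time of 72 h; a lower number here means a stronger inhibitor of growth, a higher number a weaker inhibitor of growth.
Compound 2 `N#C/C(=C\c1c[nH]c2ccccc12)C(=O)c1c[nH]c2ccccc12` gives 9300 nM in this assay.
Compound 3 `COc1ccc(CNC(=O)/C(C#N)=C/c2ccc[nH]2)cc1` gives > 50000 nM in this assay, which is a limit of the assay and not a number.

Compound 3 therefore stands at the limit of > 50000 nM in this assay, at which 1 of the 3 values shown sits, with only a bound known for it, and no number to compare directly with compound 1 or compound 2. Compound 4 `COc1ccc(CNC(=O)/C(C#N)=C/c2ccc(Br)o2)cc1` differs from compound 3 by 5-bromofuran-2-yl in place of 1H-pyrrol-2-yl on a double-bonded chain carbon bound to a double-bonded chain carbon. For the measured compounds named here, no measured pair of compounds isolates this change, so its effect has to be guessed. The step of an at least 1.1-fold lower number from compound 3 to compound 4 (0.04 log units; that floor lies within the scatter) is expected to be modest, pointing toward a somewhat stronger inhibitor but not clearly beyond the usual scatter. Compound 4 is expected to give 45000 nM, with a range from 12000 nM to 150000 nM, and may well again return only a limit.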

Compound 4, concentration for 50% growth inhibition: 12000 nM
For compound 4 the middle estimate is 3.8-fold (0.57 log units) above the measured one; measured number inside the range.
By their numbers in this assay, from the lowest: compounds 2 and 4 (each within the scatter of the next); then compound 1.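

Compound 3 gives > 50000 nM, which is a limit of the assay and not a number. Putting 5-bromofuran-2-yl in place of 1H-pyrrol-2-yl on a double-bonded chain carbon bound to a double-bonded chain carbon gives an at least 4.1-fold lower number from compound 3 to compound 4 (0.61 log units; beyond the scatter) in this assay, so the group at this place matters for growth inhibition. Only the smallest possible size of this step is known, and the true step may be larger.

As far as these compounds go, whether the bromine or the change of ring carries the step stays open. A plain furan-2-yl group at this place would help to separate the two.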